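A Methyl for Chloro Swap in a Close Series

This account rests on a few compounds, and the source may have more. Where it says the series, first, only, none or still open, it means among the compounds named here.

In an in vitro ADME assay on microsomes from liver (Mus musculus) for pharmacokinetics, read by LC-MS, with a stated time of 10 min, tested at 1 uM (on this read-out lower numbers stand for slow clearance and higher numbers for fast clearance), compound 1 `CN1C[C@H](C(=O)Nc2ccccc2)[C@@H](c2ccc(/C=C/C(=O)Nc3ccccc3N)cc2)C1` gives 67 mL/min/kg while compound 2 `CN1C[C@H](C(=O)Nc2cccc(F)c2)[C@@H](c2ccc(/C=C/C(=O)Nc3ccccc3N)cc2)C1` gives 56 mL/min/kg and compound 3 `CN1C[C@H](C(=O)Nc2cccc(Cl)c2)[C@@H](c2ccc(/C=C/C(=O)Nc3ccccc3N)cc2)C1` gives 58 mL/min/kg on the same read-out. Compound 3 therefore stands level with the other two, since all three lie within the scatter of one another. Compound 4 `Cc1cccc(NC(=O)[C@H]2CN(C)C[C@@H]2c2ccc(/C=C/C(=O)Nc3ccccc3N)cc2)c1` differs from compound 3 by methyl in place of chloro on an aromatic carbon. Among the compounds with values here, no measured step involves methyl, but three exchange hydrogen, fluoro and chloro: a 1.2-fold lower number from compound 1 to compound 2 (0.08 log units; within the scatter) and a 1.2-fold lower number from compound 1 to compound 3 (0.06 log units; within the scatter) and a 1.0-fold higher number from compound 2 to compound 3 (0.02 log units; within the scatter) are all small. No step beyond the scatter is therefore expected in this assay for this swap. The estimated step is a 1.0-fold higher number from compound 3 to compound 4 (0.01 log units; within the scatter) in size. Compound 4 is expected to show 60 mL/min/kg in this read-out, with an estimated range of 38 mL/min/kg to 90 mL/min/kg overall.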

Compound 4, clearance: 74 mL/min/kg
Compound 4: middle estimate off by 1.2-fold (0.09 log units), on the low side, within the range that was stated.
By their numbers in this assay, from the lowest: compounds 2, 3, 1 and 4 (each within the scatter of the next).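

Methyl now joins hydrogen, fluoro and chloro at this place on the aromatic ring, and in this assay every swap to it stays within the scatter: a 1.3-fold higher number from compound 3 to compound 4 (0.11 log units; within the scatter) and a 1.3-fold higher number from compound 2 to compound 4 (0.12 log units; within the scatter) and a 1.1-fold higher number from compound 1 to compound 4 (0.04 log units; within the scatter). Across these four small groups, then, clearance in mouse liver microsomes does not separate at this place. Nothing shown gives a reason for this. Still open, going by these compounds, is whether an amine, a carboxylic acid or a longer chain at the same place would move the number beyond the scatter.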